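A few compounds are considered here, and "the series" means these few. Any claim that something is new, unique, unknown or untested is made for them only; others in the source may bear on it.

Measured so far:
- compound 1 `Fc1ccccc1-c1cn2ccnc2c(-c2ccc3ncn(C4CCCCC4)c3c2)n1` — 9.1%
- compound 2 `c1csc(-c2cn3ccnc3c(-c3ccc4ncn(C5CCCCC5)c4c3)n2)c1` — 5.33%

In a functional assay on A549 cells (Homo sapiens) for inhibition, read by sulforhodamine B assay, with a stated time of 48 h, tested at 10 uM (on this read-out higher numbers stand for more inhibition at the one concentration tested (going by the name of the read-out) and lower numbers for less inhibition), compound 1 gives 9.1% and compound 2 gives 5.33%. Among the measured compounds shown here, compound 2 holds the lowest of the two numbers, but the single measured step, a number 3.8 percentage points lower from compound 1 to compound 2 (within the scatter), lies within the scatter, so the two cannot be told apart on this read-out.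

Compound 3 `FC(F)(F)c1cccc(-c2cn3ccnc3c(-c3ccc4ncn(C5CCCCC5)c4c3)n2)c1` differs from compound 2 in one place: 3-(trifluoromethyl)phenyl in place of thiophen-2-yl on an aromatic carbon. For the measured compounds named here, the only step that bears on this change is a number 3.8 percentage points lower from compound 1 to compound 2 (within the scatter), which also exchanged one aromatic group for another at the same carbon of the shared core and produced nothing beyond the scatter. Both measured numbers sit at the low end of the read-out, so no step beyond the scatter is expected here either; the expected step is a number 2.7 percentage points higher from compound 2 to compound 3 (within the scatter).

Compound 3 is therefore estimated at 8%, with a range from -5% to 25%.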

Compound 3, a percentage reported as inhibition, at one concentration (the size of the read-out at that concentration, not a potency): 5.15%
For compound 3 the middle estimate is 2.9 percentage points above the measured one; the range from low to high includes it.
By their numbers in this assay, from the lowest: compounds 3, 2 and 1 (each within the scatter of the next).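

At this aromatic carbon of the shared core, this assay gives no separation among the three aromatic groups: the new steps read a number 0.2 percentage points lower from compound 2 to compound 3 (within the scatter) and a number 4 percentage points lower from compound 1 to compound 3 (within the scatter). The exchange is also a wider one in what is counted, as 3-(trifluoromethyl)phenyl brings 10 heavy atoms and no hydrogen-bond acceptor where thiophen-2-yl had 5 heavy atoms and 1 hydrogen-bond acceptor, yet the read-out shows no step beyond the scatter. No measurement at hand bears on why the numbers stay together.

From the compounds shown here alone, whether an amine, a carboxylic acid or a longer alkyl chain at this carbon would give a step beyond the scatter remains open. Also open, going by these compounds, is whether changes elsewhere on the shared core would move the numbers at all.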